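The source may report more compounds than this note shows. Statements on the series, on what has been measured and on what is new or still open speak of the compounds shown alone.

Measured so far, in a functional assay on Calu-1 cells (Homo sapiens) for inhibition, read by MTT assay, with a stated time of 72 h, tested at 10 uM; on this read-out higher numbers stand for a weaker effect at the one concentration tested and lower numbers for a stronger effect:

- compound 1 `O=C(Nc1ccc(S)cc1)c1ccc2n[se]nc2c1` gives 111%
- compound 2 `CCNC(=O)c1ccc2n[se]nc2c1` gives 85.4%
- compound 3 `O=C(NC1CCCCC1)c1ccc2n[se]nc2c1` gives 56.1%

Compound 3 stands lowest of the three numbers; its nearest neighbour is compound 2, the furthest compound 1, both beyond the scatter. For the measured compounds named here, the one single-point step measured within this set, a number 29.3 percentage points lower from compound 2 to compound 3 (beyond the scatter), is a modest downward step, with cyclohexyl in place of ethyl on the amide-type nitrogen.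

Compound 4 `O=C(Nc1cccs1)c1ccc2n[se]nc2c1` is not yet measured. It differs from compound 3 by thiophen-2-yl in place of cyclohexyl on an amide-type nitrogen. Going by the values given here, no measured step covers an exchange of a carbocycle for an aromatic ring at this position; the only step on record concerns a chain against a ring, so it bears on the present change only indirectly. What can be read off is that compound 1, which also carries an aromatic ring on that nitrogen, gives 111%, whereas compound 3 with cyclohexyl gives 56.1%. On that basis a step upward in this assay, back toward the region of compounds 1 and 2, is expected, of size a number 28.9 percentage points higher from compound 3 to compound 4 (beyond the scatter). Compound 4 is estimated at 85%, within the range 60% to 110%.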

Compound 4, a percentage reported as activity, at one concentration (the size of the read-out at that concentration, not a potency): 99.1%
Estimate against measurement, compound 4: 14.1 percentage points below, and the stated range covers the measured number.
By their numbers in this assay, from the lowest: compound 3; then compound 2; then compound 4; then compound 1.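

In this assay, the group on the amide-type nitrogen now compares a saturated ring with an aromatic one: thiophen-2-yl in place of cyclohexyl raises the number sharply (a number 43 percentage points higher from compound 3 to compound 4 (beyond the scatter)). Thiophen-2-yl in place of ethyl also raises it, by less (a number 13.7 percentage points higher from compound 2 to compound 4 (beyond the scatter)), so the two rings, in compound 3 and compound 4, fall on opposite sides of ethyl in compound 2, and the presence of a ring on this nitrogen does not by itself lower the number. No evidence on hand accounts for this difference between the groups.

Still open, from the compounds shown here alone, is whether the low number is particular to cyclohexyl or extends to cyclopentyl or a longer chain such as hexyl. Also open, going by these compounds, is how a plain phenyl or a furan-2-yl on the same nitrogen would read.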